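Swapping a Bromophenyl Arm for a Methoxy Group

The compounds below may be only part of what the source reports. "The series", "measured", "known", "first", "only" and "open" are said of these compounds alone.

Compound 1 `CC(C)(C)n1cc2c(n1)C(=O)CC1(CCN(C(=O)c3cc(-c4ccc(F)cc4)nc4ccccc34)CC1)O2` in a functional assay on MDA-MB-231 cells (Homo sapiens) for inhibition, read by MTT assay, with a stated time of 72 h (a lower number here means a stronger inhibitor, a higher number a weaker inhibitor), gives > 10000 nM, a limit of the assay and not a number.
Compound 2 `CC(C)(C)n1cc2c(n1)C(=O)CC1(CCN(C(=O)c3cc(-c4ccc(Br)cc4)nc4ccccc34)CC1)O2` in this assay gives > 10000 nM, again a limit and not a number.
Compound 3 `Cc1cc(C(=O)N2CCC3(CC2)CC(=O)c2nn(C(C)(C)C)cc2O3)c2ccccc2n1` in this assay gives 4860 nM.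

Compound 2 thus stands at the limit of > 10000 nM in this assay, at which 2 of the 3 values shown sit, and its step from compound 1, a step that the two limits leave unreadable from compound 1 to compound 2, cannot be read because both ends are limits. For the measured compounds named here, the one readable step from compound 2 leads to compound 3: an at least 2.0-fold lower number from compound 2 to compound 3 (0.31 log units; beyond the scatter), a change whose true size may be larger, since compound 2 has only a limit.

The unmeasured compound 4 `COc1cc(C(=O)N2CCC3(CC2)CC(=O)c2nn(C(C)(C)C)cc2O3)c2ccccc2n1` differs from compound 2 in one place: methoxy in place of 4-bromophenyl on an aromatic carbon. Both compound 3 and compound 4 replace the same 4-bromophenyl with a small group, methyl in one case and methoxy in the other, so the step from compound 2 to compound 3 is the closest guide. By that comparison compound 4 is expected to give a number lower than the limit, of roughly the size seen for compound 3. Compound 4 is therefore estimated at 5000 nM, with a range from 2000 nM to 15000 nM. That estimate means an expected step of an at least 2.0-fold lower number from compound 2 to compound 4 (0.30 log units; that floor lies within the scatter).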

Compound 4, half-maximal inhibitory concentration: > 10000 nM
Compound 4 gave a limit, no number; the forecaster's own chance of this, stated with the estimate: 35%; middle value at least 2.0-fold (0.30 log units) from the limit.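

Compound 4 joins compound 1 and compound 2 at a limit of the assay, which is not a number: the limit of > 10000 nM in this assay, at which 3 of the 4 values shown sit.

The earlier compounds shown here left open the simple reading that any small group in place of the large aromatic arm would bring a measurable number. Replacing methyl with methoxy on this aromatic carbon, next to the ring nitrogen, gives an at least 2.0-fold higher number from compound 3 to compound 4 (0.31 log units; beyond the scatter), so the identity of the small group counts here, and removing the arm is not enough on its own. The steps from compound 1 and compound 2 to compound 4 cannot be read, as both ends of each are limits, which leaves compound 3 as the only one of the four with a measured number.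

As far as these compounds go, with only methyl and methoxy as small groups, two compounds cannot show what separates them, and the true size of their step stays unknown while compound 4 has only a limit. From the compounds shown here alone, whether an ethyl group, a chlorine atom or an amine at this position would give a number like that of compound 3, or fall to the limit, remains open.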